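The compounds below may be only part of what the source reports. "The series", "measured", "known", "first", "only" and "open" are said of these compounds alone.

The measured compounds in a functional assay on SW480 cells (Homo sapiens) for cytotoxicity, read by MTT assay, with a stated time of 4 days; a lower number here means a stronger inhibitor, a higher number a weaker inhibitor:

compound 1, `C=C1C(=O)[C@]23C[C@@]1(O)CC[C@H]2c1ccc(O)c(C)c1[C@@H]3Cn1cc(-c2ccccc2)nn1`: 260 nM
compound 2, `C=C1C(=O)[C@]23C[C@@]1(O)CC[C@H]2c1ccc(O)c(C)c1[C@@H]3Cn1cc(-c2ccc(C(F)(F)F)cc2)nn1`: 370 nM
compound 3, `C=C1C[C@]23C[C@@]1(O)CC[C@H]2c1ccc(OS(=O)(=O)c2ccc(C)cc2)c(C)c1[C@@H]3Cn1cc(-c2ccccc2)nn1`: > 20000 nM

Compound 1 and compound 2 share one core and differ in a single place, (trifluoromethyl in place of hydrogen on an aromatic carbon). In this assay that change gives a 1.4-fold higher number from compound 1 to compound 2 (0.15 log units; within the scatter), so the two compounds cannot be told apart on this read-out. Compound 3 carries a different core; the difference between the core of compound 1 and the core of compound 3 is not broken down here. For compound 3 the assay returns no number but a limit, > 20000 nM. That is the limit of > 20000 nM in this assay, at which 1 of the 3 values shown sits.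

Compound 4, `C=C1C[C@]23C[C@@]1(O)CC[C@H]2c1ccc(OS(=O)(=O)c2ccc(C)cc2)c(C)c1[C@@H]3Cn1cc(-c2ccc(C(F)(F)F)cc2)nn1`, has not yet been measured. It stands to compound 3 as compound 2 stands to compound 1: trifluoromethyl in place of hydrogen on an aromatic carbon. The place of the change reads the same in both pairs, so this is the same change made on a second core. Among the measured compounds shown here, the only guide to its effect is the step from compound 1 to compound 2, a 1.4-fold higher number from compound 1 to compound 2 (0.15 log units; within the scatter), which lies within the scatter. The expected step for compound 4 is a step that the limit leaves unreadable from compound 3 to compound 4. Because compound 3 sits at the limit of > 20000 nM in this assay, at which 1 of the 3 values shown sits, no number is there to move from, and a small step from a limit most likely lands at a limit again. Compound 4 is therefore expected to give a limit as well, with a middle estimate of 30000 nM and a range from 10000 nM to 100000 nM.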

Compound 4, half-maximal inhibitory concentration: > 20000 nM
Compound 4: no number, only a limit (the forecaster's own chance of this, stated with the estimate: 85%); the middle value does not contradict the limit.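

In this assay compound 4 gives > 20000 nM, which is a limit and not a number. Among the compounds shown here, compound 3 also gives only a limit, so no step between compound 3 and compound 4 can be read: the limit of > 20000 nM in this assay, at which 2 of the 4 values shown sit. The compounds shown leave open what number either compound would give, and whether trifluoromethyl in place of hydrogen changes the read-out on this core as little as on the core of compound 1.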